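The source may hold more compounds than are shown below. What is called first, only, known or untested is meant among the compounds shown, and "the series" means these compounds.

Measured so far:
Compound 1, `FC(F)(F)c1ccc(COc2nc3ccccc3s2)cc1`: 99.6%
Compound 2, `Clc1ccc(OCCOc2nc3ccccc3s2)cc1`: 68.6%
Compound 3, `c1ccc(OCCOc2nc3ccccc3s2)cc1`: "not active" (no number reported)

Of the compounds shown here, three sharing one core have been tested in a functional assay on the whole organism with Mus musculus as the target, in the writhing test, at a dose of 100 mg/kg by the intraperitoneal route; a higher number here means more inhibition at the dose given (going by the name of the read-out), a lower number less inhibition. Compound 1 gives 99.6%, the highest of the two numbers reported. Compound 2 gives 68.6%, a gap to compound 1 that lies beyond the usual scatter of this assay. Compound 3 is reported as "not active" (no number reported), without a number.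

The next compound, compound 4, `Clc1ccc(COc2nc3ccccc3s2)cc1`, has not yet been measured. It differs from compound 1 in one place: chloro in place of trifluoromethyl on an aromatic carbon. Among the compounds with values here, no measured pair shows this change directly, so its effect can only be guessed. Compound 2, which also carries a chloro group though on a different linker, gives 68.6%, below the value of compound 1. A modest drop from compound 1 is therefore expected, with the step from compound 1 to compound 4 estimated at a number 21.6 percentage points lower from compound 1 to compound 4 (beyond the scatter). Compound 4 is expected to give about 78%, within a range from 45% to 100%.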

Compound 4, a percentage reported as inhibition, in the whole organism at one dose (the size of the read-out at that dose, not a potency): 51.9%
For compound 4 the middle estimate is 26.1 percentage points above the measured one, and the stated range covers the measured number.
By their numbers in this assay, from the lowest: compound 4; then compound 2; then compound 1.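

Replacing trifluoromethyl with chloro on this aromatic carbon, para to a large group, gives a number 47.7 percentage points lower from compound 1 to compound 4 (beyond the scatter) in this assay. Within the data shown here, this is the first direct comparison at this position, and it shows that the group placed there strongly affects the inhibition seen at this single dose. The change does not remove the effect entirely, as compound 4 still gives 51.9%. Nothing measured here explains the size of this step.

On these data alone, one swap at one position does not establish a trend, so it remains open how a methoxy group, a fluoro group or an amine on the same carbon would compare with trifluoromethyl and chloro. As far as these compounds go, it is also open whether this swap would have a similar effect on the linker carried by compound 2.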